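The source may hold more compounds than are shown below. What is called first, only, known or untested is meant among the compounds shown, and "the series" means these compounds.

The measured compounds:
compound 1 `CNC(=O)c1ccc(Oc2cccc(NC(=S)Nc3ccc(F)c(C(F)(F)F)c3)c2)nc1`: 13300 nM
compound 2 `CNC(=O)c1ccc(Oc2cccc(NC(=S)Nc3ccc(OC)cc3)c2)nc1`: 31500 nM
compound 3 `CNC(=O)c1ccc(Oc2cccc(NC(=S)Nc3cccc(C(F)(F)F)c3)c2)nc1`: 38100 nM

In a functional assay on MDA-MB-231 cells (Homo sapiens) for antiproliferative activity, read by MTT assay (a lower number here means a stronger inhibitor, a higher number a weaker inhibitor), compound 3 gives the highest of the three numbers, though compound 2 sits within the scatter of it; only compound 1 stands clearly apart, with a lower value. Compound 4 `CNC(=O)c1ccc(Oc2cccc(NC(=S)Nc3ccc(Br)c(C(F)(F)F)c3)c2)nc1` differs from compound 3 by bromo in place of hydrogen on an aromatic carbon. The step that bears on this change is a 2.9-fold higher number from compound 1 to compound 3 (0.46 log units; beyond the scatter), where a halogen was removed from the same aromatic carbon and the number rose. Putting a halogen back there is therefore expected to bring the number down again by a modest amount, with a step of a 2.5-fold lower number from compound 3 to compound 4 (0.40 log units; beyond the scatter) anticipated. Compound 4 is accordingly estimated at 15000 nM, with a range from 6000 nM to 40000 nM.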

Compound 4, half-maximal inhibitory concentration: 3020 nM
Estimate against measurement, compound 4: 5.0-fold (0.70 log units) above, outside the stated range (below it).
By their numbers in this assay, from the lowest: compound 4; then compound 1; then compounds 2 and 3 (each within the scatter of the next).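

At this aromatic carbon, ortho to a trifluoromethyl group, adding a halogen can do far more than the fluoro comparison suggested, since bromo in place of hydrogen gives in this assay a large change (a 13-fold lower number from compound 3 to compound 4 (1.10 log units; beyond the scatter)). The choice of halogen also counts, as bromo in place of fluoro gives a further change beyond the scatter (a 4.4-fold lower number from compound 1 to compound 4 (0.64 log units; beyond the scatter)). Nothing available explains this difference between the halogens at this position. On these data alone, whether chloro or iodo would fall between or beyond these values remains open, as does how an amine at this carbon would compare.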